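Trimming the Phenethyl Chain to a Propyl Group

A few compounds are considered here, and "the series" means these few. Any claim that something is new, unique, unknown or untested is made for them only; others in the source may bear on it.

Measured so far:
compound 1 `COc1cccc(-c2nc3c(-c4ccc(Cl)cc4)n[nH]c3c(=O)n2NC(=O)c2ccccc2)c1` — 17900 nM
compound 2 `O=C(Nn1c(CCc2ccccc2)nc2c(-c3ccc(Cl)cc3)n[nH]c2c1=O)c1ccccc1` — 86700 nM

Both compounds were tested in a functional assay on DU-145 cells (Homo sapiens) for inhibition, read by MTT assay, with a stated time of 2 days; a lower number here means a stronger inhibitor of growth, a higher number a weaker inhibitor of growth. Compound 1 gives 17900 nM, and compound 2 gives 86700 nM. Compound 2 therefore shows the higher of the two numbers, and the step of a 4.8-fold higher number from compound 1 to compound 2 (0.69 log units; beyond the scatter) lies beyond the scatter, so swapping the 3-methoxyphenyl group for a phenethyl chain clearly weakened growth inhibition.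

Compound 3 `CCCc1nc2c(-c3ccc(Cl)cc3)n[nH]c2c(=O)n1NC(=O)c1ccccc1` has not yet been measured. It differs from compound 2 by methyl in place of phenyl on a saturated chain carbon, two bonds along the chain from an aromatic carbon; put another way, the phenethyl chain becomes a propyl chain. Going by the values given here, no measured step covers exactly this change, since the only measured step, a 4.8-fold higher number from compound 1 to compound 2 (0.69 log units; beyond the scatter), compares an aromatic group with a phenethyl chain rather than two chains. That step suggests the chain-bearing compounds sit at the weak end, but it does not tell whether losing the phenyl will help or hurt. The expectation for compound 3 in this assay is therefore a step of a 1.0-fold higher number from compound 2 to compound 3 (0.02 log units; within the scatter), near no change, with a wide range. Compound 3 is estimated at 90000 nM, between 30000 nM and 270000 nM.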

Compound 3, concentration for 50% growth inhibition: 29200 nM
Compound 3: the middle estimate sits 3.1-fold (0.49 log units) above what was measured; measured number below the stated range.
By their numbers in this assay, from the lowest: compounds 1 and 3 (each within the scatter of the next); then compound 2.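

In this assay, the end of the chain matters at this position: with methyl in place of phenyl on a saturated chain carbon, two bonds along the chain from an aromatic carbon, growth inhibition becomes stronger by more than the scatter (a 3.0-fold lower number from compound 2 to compound 3 (0.47 log units; beyond the scatter)). The earlier pair could not show this, since it compared an aromatic group with a chain and left open whether any chain in this place gives a weak inhibitor. Propyl and 3-methoxyphenyl on this aromatic carbon are within the scatter of each other (a 1.6-fold higher number from compound 1 to compound 3 (0.21 log units; within the scatter)), so among these three compounds the weakening goes with the phenethyl chain, not with a chain as such, and no measurement at hand explains the effect of removing the phenyl.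

Going by these compounds, all three numbers remain high on this scale, and it stays open whether a shorter chain such as ethyl or a longer one such as butyl would move growth inhibition in either direction. On these data alone, it is also open whether an amine or a carboxylic acid at the end of the propyl chain would be tolerated as well as the methyl end of compound 3.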